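Chroman thiazolidinediones: notes toward compound 4

The compounds below may be only part of what the source reports. "The series", "measured", "known", "first", "only" and "open" are said of these compounds alone.

Measured so far, in a functional assay on MCF7 cells (Homo sapiens), tested at 7.5 uM; on this read-out lower numbers stand for a stronger effect and higher numbers for a weaker effect at the one concentration tested:
compound 1, `CC(C)=CCOc1c(C)c(C)c2c(c1C)CCC(C)(COc1ccc(/C=C3\SC(=O)NC3=O)cc1C)O2`, gives 27%
compound 2, `C=CCOc1c(C)c(C)c2c(c1C)CCC(C)(COc1ccc(/C=C3\SC(=O)NC3=O)cc1OCC)O2`, gives 75%
compound 3, `Cc1c(C)c2c(c(C)c1OC(=O)CCC(=O)O)CCC(C)(COc1ccc(/C=C3\SC(=O)NC3=O)cc1)O2`, gives 76%

Compound 3 carries the highest number of the three. Compound 2 sits within the scatter of it; compound 1 lies beyond the scatter, at a lower number. Compound 4, `CC(C)=CCOc1c(C)c(C)c2c(c1C)CCC(C)(COc1ccc(/C=C3\SC(=O)NC3=O)cc1)O2`, is not yet measured. It differs from compound 3 by 3-methylbut-2-en-1-yl in place of (2-carboxyethyl)carbonyl on an oxygen on an aromatic ring. Among the measured compounds shown here, no pair of measured compounds isolates this change. Compound 1 carries the same 3-methylbut-2-en-1-yl group and gives 27%, though it differs elsewhere too. The expected step is a number 31 percentage points lower from compound 3 to compound 4 (beyond the scatter), toward a lower number, beyond the scatter. Compound 4 is estimated at 45%, within 20% to 75%.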

Compound 4, a percentage reported as activity, at one concentration (the size of the read-out at that concentration, not a potency): 5%
For compound 4 the middle estimate is 40 percentage points above the measured one, outside the stated range (below it).
By their numbers in this assay, from the lowest: compound 4; then compound 1; then compounds 2 and 3 (each within the scatter of the next).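

In this assay the change on an oxygen on an aromatic ring can now be read in one place: 3-methylbut-2-en-1-yl in place of (2-carboxyethyl)carbonyl gives a number 71 percentage points lower from compound 3 to compound 4 (beyond the scatter) as a large step. With 3-methylbut-2-en-1-yl held constant, hydrogen in place of methyl on an aromatic carbon gives a number 22 percentage points lower from compound 1 to compound 4 (beyond the scatter) as a modest step, so this second place also moves the number. No measurement shown explains either step.

Open, as far as these compounds go, is how an amine or a longer chain on that oxygen would compare with 3-methylbut-2-en-1-yl. Also open, from the compounds shown here alone, is whether the step from methyl to hydrogen carries over to compounds with other groups on that oxygen.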